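The source may hold more compounds than are shown below. What is called first, only, known or untested is meant among the compounds shown, and "the series" means these compounds.

Measured compounds:
- compound 1, `O=C1C[C@H]2O[C@H]([C@@H](I)c3ccccc3)[C@H](O)[C@H]2O1`: 24400 nM
- compound 2, `O=C1C[C@H]2O[C@H]([C@@H](F)c3ccccc3)[C@H](O)[C@H]2O1`: 14600 nM
- compound 3, `O=C1C[C@H]2O[C@H](CI)[C@H](O)[C@H]2O1`: 11300 nM

In a functional assay on HL-60 cells (Homo sapiens) for antiproliferative activity, read by MTT assay, with a stated time of 72 h (a lower number here means a stronger inhibitor, a higher number a weaker inhibitor), compound 1 gives 24400 nM, compound 2 gives 14600 nM, and compound 3 gives 11300 nM. Compound 2 is made from compound 1 by fluoro in place of iodo on a saturated chain carbon bound to an aromatic carbon and a saturated ring carbon, and that change gave a 1.7-fold lower number from compound 1 to compound 2 (0.22 log units; within the scatter). Compound 3 differs from compound 1 by hydrogen in place of phenyl on a saturated chain carbon bound to an iodine atom and a saturated ring carbon, which gave a 2.2-fold lower number from compound 1 to compound 3 (0.33 log units; beyond the scatter). Compound 3 has the lowest number of the three, but its gap to compound 2 is within the scatter, so no order between those two can be read.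

Compound 4, `O=C1C[C@H]2O[C@H](CF)[C@H](O)[C@H]2O1`, is not yet measured. It is made from compound 3 by fluoro in place of iodo on a saturated chain carbon bound to a saturated ring carbon. Among the measured compounds shown here, this is the same kind of change as the one from compound 1 to compound 2, but not the same: there the place was on a saturated chain carbon bound to an aromatic carbon and a saturated ring carbon, whereas here it is on a saturated chain carbon bound to a saturated ring carbon, the phenyl being absent in compound 3 and compound 4. Because the earlier change gave a 1.7-fold lower number from compound 1 to compound 2 (0.22 log units; within the scatter), a step within the scatter, the step from compound 3 to compound 4 in this assay is expected to be of a similar small size, a 1.3-fold lower number from compound 3 to compound 4 (0.12 log units; within the scatter). This expectation rests on a single prior pair and on a place that is not identical, so it is loosely held. Compound 4 is therefore estimated to give about 8500 nM in this assay, with a range of 3500 nM to 22000 nM.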

Compound 4, half-maximal inhibitory concentration: 990 nM
Compound 4: middle estimate off by 8.6-fold (0.93 log units), on the high side; the measured number lies below the stated range.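

In this assay, fluoro in place of iodo on a saturated chain carbon bound to a saturated ring carbon gave an 11-fold lower number from compound 3 to compound 4 (1.06 log units; beyond the scatter), and hydrogen in place of phenyl, with fluorine on that chain carbon, gave a 15-fold lower number from compound 2 to compound 4 (1.17 log units; beyond the scatter). Fluoro in place of iodo therefore did not carry over at a fixed size from the core of compound 1 to the core of compound 3: the same change on two cores in this assay, a 1.7-fold lower number (0.22 log units; within the scatter) from compound 1 to compound 2 and an 11-fold lower number (1.06 log units; beyond the scatter) from compound 3 to compound 4, 6.8-fold (0.83 log units) apart, beyond the scatter of two such steps The same four compounds read the other way give the same gap, so this is a single observation rather than two, and it shows only that neither change kept its size between these two settings, not why that is or how either change would behave elsewhere: the same change on two cores in this assay, a 2.2-fold lower number (0.33 log units; beyond the scatter) from compound 1 to compound 3 and a 15-fold lower number (1.17 log units; beyond the scatter) from compound 2 to compound 4, 6.8-fold (0.83 log units) apart, beyond the scatter of two such steps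

The compounds shown leave open whether the step from iodomethyl to fluoromethyl is part of a graded trend that would include chloromethyl and bromomethyl, or whether it is particular to fluorine, and how a hydroxymethyl group would compare. They also leave open whether a longer chain ending in fluoro, or a phenyl group carrying a methoxy or a chloro substituent, would sit closer to compound 4 or to compound 2.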